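Replacing methylsulfanyl with piperidin-1-yl on compound 3

This account rests on a few compounds, and the source may have more. Where it says the series, first, only, none or still open, it means among the compounds named here.

Compound 1 `O=C(c1ccccc1)c1sc(N2CCCC2)nc1Cl`: 82000 nM
Compound 2 `O=C(c1ccccc1)c1sc(N2CCCC2)nc1Br`: > 100000 nM (a limit of the assay)
Compound 3 `COC(=O)c1sc2nc(SC)sc2c1C`: 92000 nM

All three compounds were tested in a functional assay on U-373MG ATCC cells (Homo sapiens) for cytotoxicity, read by MTT assay, with a stated time of 72 h; on this read-out higher numbers stand for weaker inhibition and lower numbers for stronger inhibition. Compound 3 gives 92000 nM and compound 1 gives 82000 nM, two numbers within the scatter of each other. The reading for compound 2 is > 100000 nM, which is a limit and not a number.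

Compound 4 `COC(=O)c1sc2nc(N3CCCCC3)sc2c1C` keeps the core of compound 3 and changes in one place: piperidin-1-yl in place of methylsulfanyl on an aromatic carbon. In short, piperidin-1-yl stands in place of methylsulfanyl on an aromatic carbon.

For the measured compounds named here, the only measured step, an at least 1.2-fold higher number from compound 1 to compound 2 (0.08 log units; that floor lies within the scatter), is a swap of bromo for chloro on a different core, so it offers no direct guide to this change. More useful is compound 1, which also carries a non-aromatic ring with nitrogen and gives 82000 nM. On that basis, no step beyond the scatter is expected in this assay. The expected change is a 1.3-fold lower number from compound 3 to compound 4 (0.12 log units; within the scatter). The assay could also report only a limit, given (the limit of > 100000 nM in this assay, at which 1 of the 3 values shown sits). For compound 4 the estimated value is 70000 nM, with an expected range from 25000 nM to 120000 nM.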

Compound 4, half-maximal inhibitory concentration: > 100000 nM
Compound 4 was reported as a limit; the forecaster's own chance of this, stated with the estimate: 35%; middle value at least 1.4-fold (0.15 log units) from the limit.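

In this assay compound 4 gives > 100000 nM, which is a limit of the assay and not a number. Putting piperidin-1-yl in place of methylsulfanyl, on this aromatic carbon next to the ring nitrogen and next to the ring sulfur, gives an at least 1.0-fold higher number from compound 3 to compound 4 (0.03 log units; that floor lies within the scatter), so the new group brings no sign of stronger inhibition of these cells, while the data cannot show a real loss either. The true size of the step stays unknown because the reading stops at the edge of what the assay reports: the limit of > 100000 nM in this assay, at which 2 of the 4 values shown sit.

The compounds shown leave open whether a smaller amine such as dimethylamino, or a ring with a second nitrogen such as piperazin-1-yl, would give a clearly lower number on this core than compound 3 gives at 92000 nM. They also leave open whether the smaller non-aromatic ring with nitrogen carried by compound 1 would read any differently from piperidin-1-yl at this position, as compound 1 carries that ring on a different core.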